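The source may report more compounds than this note shows. Statements on the series, on what has been measured and on what is new or still open speak of the compounds shown alone.

Measured so far in an assay on LX2 cells for inhibition of COL1A1 promoter (Homo sapiens), read by a luciferase reporter, with a stated time of 24 h, tested at 50 uM; a higher number here means a stronger effect of the compound at the concentration tested, a lower number a weaker effect:
- compound 1 `CN(C)c1ccc2c(=O)c(C(=O)Nc3cc(F)cc(F)c3)cn(-c3ccc(OCCCCCCC[N+]45CCN(CC4)CC5)c(Cl)c3)c2n1`: 20.5%
- compound 2 `CN(C)c1ccc2c(=O)c(C(=O)Nc3cc(F)cc(F)c3)cn(-c3ccc(OCCCCCCC[N+]4(C)CCCCC4)c(Cl)c3)c2n1`: "not active" (no number reported)
- compound 3 `CN(C)c1ccc2c(=O)c(C(=O)Nc3cc(F)cc(F)c3)cn(-c3ccc(OCCCCCCC[n+]4ccccc4)c(Cl)c3)c2n1`: 21.4%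

Compound 3 and compound 1 sit together; the step of a number 0.9 percentage points higher from compound 1 to compound 3 (within the scatter) is within the scatter, so neither can be set apart from the other. Compound 2 returned no number in this assay.

Compound 4 `CN1CC[N+](C)(CCCCCCCOc2ccc(-n3cc(C(=O)Nc4cc(F)cc(F)c4)c(=O)c4ccc(N(C)C)nc43)cc2Cl)CC1` is next: a group of 8 heavy atoms (6 carbon, 2 nitrogen; one six-membered non-aromatic ring with 2 hetero atoms) in place of a group of 6 heavy atoms (5 carbon, 1 nitrogen; one six-membered aromatic ring with 1 hetero atom), on a saturated chain carbon, seven bonds along the chain from an oxygen on an aromatic ring

For the measured compounds named here, the only step that bears on this position is a number 0.9 percentage points higher from compound 1 to compound 3 (within the scatter), where exchanging one charged group for another at the same chain carbon moved nothing beyond the scatter. Compound 2, with a charged saturated ring there, gave no number, which is the one warning. The expected step of a number 3.4 percentage points lower from compound 3 to compound 4 (within the scatter) is none beyond the scatter. Compound 4 is therefore estimated at 18%, range 5% to 30%.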

Compound 4, a percentage reported as inhibition, at one concentration (the size of the read-out at that concentration, not a potency): 15.4%
Compound 4: middle estimate off by 2.6 percentage points, on the high side; measured number inside the range.
By their numbers in this assay, from the lowest: compounds 4, 1 and 3 (each within the scatter of the next).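

In this assay the entry of the six-membered non-aromatic ring with 2 hetero atoms gives a number 6 percentage points lower from compound 3 to compound 4 (within the scatter) and a number 5.1 percentage points lower from compound 1 to compound 4 (within the scatter) at the saturated chain carbon. For the compounds shown here, a third charged group, with a net charge of +1 like the two before it, therefore cannot be set apart from either, and compound 2 stays the only entry without a number. No measurement shown accounts for these readings.

Open, as far as these compounds go, is whether a primary amine or a carboxylic acid in this place, or a shorter chain, would read differently from these charged groups.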